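Chain extension at the saturated ring carbon of compound 2

The source may hold more compounds than are shown below. What is called first, only, known or untested is meant among the compounds shown, and "the series" means these compounds.

Compound 1 `CC1Oc2ccc(OCc3ccccc3)cc2C=C1CN(O)C(N)=O` and compound 2 `CC1Oc2ccc(Oc3ccccc3)cc2C=C1CN(O)C(N)=O` share one core and differ only at the ether on the aromatic ring. In an assay (Cavia porcellus) for inhibition of Polyunsaturated fatty acid 5-lipoxygenase (Homo sapiens) (on this read-out lower numbers stand for stronger inhibition and higher numbers for weaker inhibition), compound 1 gives 260 nM and compound 2 gives 87 nM; a 3.0-fold lower number from compound 1 to compound 2 (0.48 log units; beyond the scatter). Among the measured compounds shown here, compound 2 thus holds the lowest number of the two measured, with compound 1 as its only neighbour.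

Compound 3 `CCCC1Oc2ccc(Oc3ccccc3)cc2C=C1CN(O)C(N)=O` keeps the phenyl ether of compound 2 and carries ethyl in place of hydrogen on a saturated chain carbon bound to a saturated ring carbon. For the measured compounds named here, no measured step touches this position: the single step available, a 3.0-fold lower number from compound 1 to compound 2 (0.48 log units; beyond the scatter), concerns the ether and says nothing about the chain on the saturated ring carbon. With no guide, the change is expected to leave compound 3 about where compound 2 stands in this assay. The step is therefore estimated as a 1.1-fold lower number from compound 2 to compound 3 (0.04 log units; within the scatter), not beyond the scatter. Compound 3 is expected to give 80 nM, in the range 30 nM to 250 nM.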

Compound 3, half-maximal inhibitory concentration: 870 nM
Compound 3: the middle estimate sits 11-fold (1.04 log units) below what was measured; the whole stated range lies below it.
By their numbers in this assay, from the lowest: compound 2; then compound 1; then compound 3.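

Notes on the chain: the position is not neutral in this assay, since ethyl in place of hydrogen on a saturated chain carbon bound to a saturated ring carbon, which reads equally as methyl to propyl, gives a 10-fold higher number from compound 2 to compound 3 (1.00 log units; beyond the scatter). This step is beyond the scatter, runs in the opposite direction to the ether change, a 3.0-fold lower number from compound 1 to compound 2 (0.48 log units; beyond the scatter), and is the larger of the two, so the series responds to this chain at least as clearly as to the ether. Nothing available bears on the origin of this weakening.

Open, from the compounds shown here alone, is whether the number climbs evenly with length, as an ethyl or butyl chain here would show, or whether a chain ending in an amine or a carboxylic acid behaves differently. Also open, going by these compounds, is whether propyl gives a step of similar size on the benzyl ether of compound 1.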